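Methoxy to 3-nitrophenoxy on the shared core

The source may report more compounds than this note shows. Statements on the series, on what has been measured and on what is new or still open speak of the compounds shown alone.

- compound 1 `COc1ccc([C@@H]2CC(=O)c3cc(CC=C(C)C)c(OC)cc3O2)cc1` gives 45%
- compound 2 `COc1ccc([C@@H]2C/C(=N/OCc3cn(-c4ccc(Cl)cc4C)nn3)c3cc(CC=C(C)C)c(OC)cc3O2)cc1` gives 35%

Among the compounds with values here, in a functional assay on A549 cells (Homo sapiens) for inhibition, read by sulforhodamine B assay, with a stated time of 48 h, tested at 50 uM (a lower number here means less inhibition of growth, a higher number more inhibition of growth at the concentration tested), compound 1 gives 45% and stands level with compound 2, the only other measured compound, as the two values lie within the scatter of each other. The next step leads to compound 3 `COc1cc2c(cc1CC=C(C)C)C(=O)C[C@@H](c1ccc(Oc3cccc([N+](=O)[O-])c3)cc1)O2` and alters one place: 3-nitrophenyl in place of methyl on an oxygen on an aromatic ring. Within the data shown here, no measured pair isolates this change, so the data give no direct guide to its size. Among the measured compounds shown here, the only indirect guide differs from compound 1 elsewhere in the structure: compound 2 reads 35%, within the scatter. Expected in this assay is no change at the digits printed from compound 1 to compound 3 (within the scatter), with no shift beyond the scatter in either direction. For compound 3 the estimate is 45%, with an expected range from 20% to 70%.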

Compound 3, percent growth inhibition at one concentration: 37%
Beside the measured number, compound 3's estimate is 8 percentage points above it, and the stated range covers the measured number.
By their numbers in this assay, from the lowest: compounds 2, 3 and 1 (each within the scatter of the next).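

In this assay, within the data shown here, the step of a number 8 percentage points lower from compound 1 to compound 3 (within the scatter) is the first direct reading at this position, as the earlier comparison involved a change elsewhere in the structure. On the oxygen on an aromatic ring, 3-nitrophenyl in place of methyl therefore causes no shift beyond the scatter, so this place accepts the much larger group without a measurable loss of growth inhibition at the concentration tested. Nothing at hand explains this reading.

Still open, from the compounds shown here alone, is whether a plain phenoxy, a benzyloxy or a free hydroxyl at this place would read the same, and so whether the nitro group matters at all. A single concentration also leaves open whether compound 1 and compound 3 would remain level across a full concentration range.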